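The compounds below may be only part of what the source reports. "The series", "measured", "known", "first", "only" and "open" are said of these compounds alone.

Compound 1 `COc1ccc(Oc2cc(Oc3cccnc3)ccc2C#N)cc1` is the reference for this step. In an assay on isolated protein for inhibition of Aromatase (Homo sapiens), read by fluorescence, tested at 1 uM (a lower number here means less inhibition, a higher number more inhibition at the concentration tested (going by the name of the read-out)), compound 1 gives 84%, the highest of the two numbers in hand. Compound 2 `CN1CCN(c2cc(Oc3cccnc3)ccc2C#N)CC1` gives 8% in this assay, a gap from compound 1 that is beyond the scatter. Compound 3 `N#Cc1ccc(Oc2cccnc2)cc1Oc1cccc(Cl)c1` is not yet measured. Against compound 1, the change is 3-chlorophenyl in place of 4-methoxyphenyl on an oxygen on an aromatic ring. Among the compounds with values here, no measured pair isolates a change of this kind, so the step of a number 10 percentage points lower from compound 1 to compound 3 (within the scatter) is expected to be modest, more likely downward than upward. The estimate for compound 3 in this assay is 74%, with a range from 45% to 92%.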

Compound 3, a percentage reported as inhibition, at one concentration (the size of the read-out at that concentration, not a potency): 25%
Compound 3: middle estimate off by 49 percentage points, on the high side; the measured number lies below the stated range.
By their numbers in this assay, from the lowest: compound 2; then compound 3; then compound 1.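

In this assay the group on this oxygen is not interchangeable: 3-chlorophenyl in place of 4-methoxyphenyl gives a number 59 percentage points lower from compound 1 to compound 3 (beyond the scatter) and so takes away most of the inhibition seen with compound 1. The change alters both the group on the phenyl and its printed number, so the step cannot be assigned to either part alone. Nothing in hand bears on the reason for this step. 3-methoxyphenyl and 4-chlorophenyl would separate those two parts. As far as these compounds go, the outcome with an amine or a carboxylic acid on this phenyl remains open.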